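A few compounds are considered here, and "the series" means these few. Any claim that something is new, unique, unknown or untested is made for them only; others in the source may bear on it.

Measured so far:
compound 1, `COC(=O)c1cc(-c2cccc(NC(=O)c3ccc(/C=C/C(=O)c4cccc(C(F)(F)F)c4)cc3)c2)on1`, in an ADME assay on Vero cells (Chlorocebus sabaeus) for cytotoxicity, read by MTT assay, with a stated time of 72 h; a higher number here means that more compound is tolerated, a lower number that less compound is tolerated: > 20 ug/mL
compound 2, `COC(=O)c1cc(-c2cccc(NC(=O)c3ccc(/C=C/C(=O)c4ccccc4O)cc3)c2)on1`, in this assay gives compound 2 "not determined" (no result reported).

The value of compound 1 in this assay is a limit of the assay, not a number: the limit of > 20 ug/mL in this assay, at which 1 of the 2 values shown sits. Compound 2 stands without any number in this assay; of the two values shown, one is that limit. Compound 3, `COC(=O)c1cc(-c2cccc(NC(=O)c3ccc(/C=C/C(=O)c4ccc(Cl)cc4)cc3)c2)on1`, is not yet measured. It differs from compound 2 by 4-chlorophenyl in place of 2-hydroxyphenyl on a carbonyl carbon. For the measured compounds named here, no measured step between these compounds exists, so no direction can be drawn from the data; the step expected in this assay is none beyond the scatter. Compound 3 is expected to give 25 ug/mL in this assay, within 10 ug/mL to 60 ug/mL.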

Compound 3, half-maximal cytotoxic concentration: > 50 ug/mL
Compound 3: no number, only a limit; the forecaster's own chance of this, stated with the estimate: 70%; middle value at least 2.0-fold (0.30 log units) away from the limit.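

No new step can be read in this assay: compound 1 and compound 3 each give a limit, not a number, and compound 2 gives no number. Still open, as far as these compounds go, is whether 4-chlorophenyl and 3-(trifluoromethyl)phenyl differ in tolerated concentration.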